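The compounds below may be only part of what the source reports. "The series", "measured", "known", "first", "only" and "open" are said of these compounds alone.

Three compounds share one core and differ only in the group carried on an amide-type nitrogen. Compound 1 `CNC(=O)c1cc(C(=O)N[C@H]2CC[C@H](O)CC2)n([C@@H](C)c2ccccc2)n1` gives 2.9 in a physicochemical assay for lipophilicity; on this read-out higher numbers stand for higher lipophilicity and lower numbers for lower lipophilicity. Compound 2 `CNC(=O)c1cc(C(=O)N[C@H]2[C@@H]3C[C@@H](O)C[C@@H]32)n([C@@H](C)c2ccccc2)n1` gives 3.2 in this assay, a step of a number 0.30 log units higher from compound 1 to compound 2 (within the scatter). Compound 3 `CCNC(=O)c1cc(C(=O)NC)nn1[C@@H](C)c1ccccc1` gives 3.7 in this assay, the highest of the three, reached through steps of a number 0.80 log units higher from compound 1 to compound 3 (beyond the scatter) and a number 0.50 log units higher from compound 2 to compound 3 (beyond the scatter). Compound 4 `CCCNC(=O)c1cc(C(=O)NC)nn1[C@@H](C)c1ccccc1` has not yet been measured in this assay; it differs from compound 3 by methyl in place of hydrogen on a saturated chain carbon, two bonds along the chain from an amide-type nitrogen. Within the data shown here, none of the measured steps is of this kind: each of them swaps a ring-bearing group for a short chain, and none adds a single carbon to an existing chain, so the measured steps give only loose guidance. Compound 4 is expected to give 4.1 in this assay, between 3.7 and 4.5, an estimated step of a number 0.40 log units higher from compound 3 to compound 4 (beyond the scatter).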

Compound 4, distribution coefficient: 4.4
For compound 4 the middle estimate is 0.30 log units below the measured one, within the range that was stated.
By their numbers in this assay, from the lowest: compounds 1 and 2 (each within the scatter of the next); then compound 3; then compound 4.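

Lengthening ethyl to propyl on this amide-type nitrogen gives a number 0.70 log units higher from compound 3 to compound 4 (beyond the scatter) in this assay, the first measured step that extends a chain here rather than replacing a ring-bearing group. Set against those ring-bearing groups, propyl gives a number 1.20 log units higher from compound 2 to compound 4 (beyond the scatter) and a number 1.50 log units higher from compound 1 to compound 4 (beyond the scatter) in this assay, so the gaps widen beyond those seen with ethyl. Nothing at hand accounts for the size of these steps. From the compounds shown here alone, whether a longer chain such as butyl would keep raising the number remains open, since one added carbon shows no trend. Going by these compounds, how a propyl chain ending in an amine or a carboxylic acid would read is also open.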